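The source may report more compounds than this note shows. Statements on the series, on what has been measured and on what is new or still open speak of the compounds shown alone.

Measured so far:
Compound 1 `Nc1ccccc1NC(=O)/C=C/c1ccc(CSc2ccc(F)cc2)cc1` gives 18.3% in a functional assay on SMMC-7721 cells (Homo sapiens) for inhibition, read by CCK-8 assay, with a stated time of 72 h, tested at 2 uM; a higher number here means more inhibition of growth at the concentration tested, a lower number less inhibition of growth.
Compound 2 `Nc1ccccc1NC(=O)/C=C/c1ccc(CSCCc2ccccc2)cc1` gives 14.7% in this assay.
Compound 3 `Nc1ccccc1NC(=O)c1ccc(CSCCc2ccccc2)cc1` gives 28.1% in this assay.

Compounds 2 and 1 share a core and differ in one place: 4-fluorophenyl in place of phenethyl on a sulfur. This swap gave a number 3.6 percentage points higher from compound 2 to compound 1 (within the scatter), so it did not change growth inhibition in a way that can be told apart from noise. Compound 3 carries the same phenethyl group on its sulfur but a different core; the difference between the two cores is not broken down here. Its value and that of compound 1 lie within the scatter of each other, while its value stands beyond the scatter above that of compound 2.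

Compound 4 `Nc1ccccc1NC(=O)c1ccc(CSc2ccc(F)cc2)cc1` is not yet measured. It relates to compound 3 as compound 1 relates to compound 2: 4-fluorophenyl in place of phenethyl on a sulfur. The place is described in the same words for both pairs, so this is the same change. Going by the values given here, the only guide is the step seen in compounds 2 and 1, which was a number 3.6 percentage points higher from compound 2 to compound 1 (within the scatter), so the expected step is a number 2.9 percentage points higher from compound 3 to compound 4 (within the scatter), also within the scatter. Compound 4 is therefore estimated at 31% in this assay, expected between 17% and 45%.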

Compound 4, percent growth inhibition at one concentration: 6.58%
The estimate for compound 4 lay 24.4 percentage points above the measured number, and the stated range ends above it.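

In this assay, putting 4-fluorophenyl in place of phenethyl on a sulfur gave a number 21.5 percentage points lower from compound 3 to compound 4 (beyond the scatter), a clear loss of growth inhibition on this core. The same swap therefore does not carry over unchanged from one core to the other: the same change on two cores in this assay, a number 3.6 percentage points higher (within the scatter) from compound 2 to compound 1 and a number 21.5 percentage points lower (beyond the scatter) from compound 3 to compound 4, 25.1 percentage points apart, beyond the scatter of two such steps. In these two pairs, the outcome of the swap depends on the core, but two pairs give no rule for other cores and do not show which feature of the core matters or why.

Going by these compounds, it stays open how a longer chain on the sulfur, or a group carrying an amine or a carboxylic acid, would behave on either core. Also open, on these data alone, is what a plain phenyl on the sulfur would do on each core, which could help separate the part played by the fluorine from the part played by the chain in phenethyl.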